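The compounds below may be only part of what the source reports. "The series", "measured", "known", "first", "only" and "open" are said of these compounds alone.

Measured so far:
compound 1, `COc1cccc(S(=O)(=O)Nc2ccc3oc(-c4ccccc4)nc3c2)c1`, in an ADME assay on HEK293 cells (Homo sapiens) for cytotoxicity, read by resazurin assay, with a stated time of 48 h; on this read-out lower numbers stand for higher toxicity in this test and higher numbers for lower toxicity in this test: 63000 nM
compound 2, `O=S(=O)(Nc1ccc(-c2nc3ccccc3o2)cc1)c1ccc(F)cc1`: > 100000 nM

Compound 1 gives 63000 nM in this assay. Compound 2 reaches only a limit of the assay, > 100000 nM, which is not a number. Compound 1 therefore holds the only real number shown, the other value being (the limit of > 100000 nM in this assay, at which 1 of the 2 values shown sits). The new compound 3 `O=S(=O)(Nc1ccc2oc(-c3ccccc3)nc2c1)c1ccc(Cl)s1` differs from compound 1 in one place: 5-chlorothiophen-2-yl in place of 3-methoxyphenyl on a sulfonyl sulfur. For the measured compounds named here, no measured pair of compounds shows this change, so the size of the step can only be guessed. A small move toward higher toxicity in this assay appears plausible, but a step that stays within the usual scatter is just as likely. The expected step from compound 1 to compound 3 is a 1.3-fold lower number from compound 1 to compound 3 (0.10 log units; within the scatter). Compound 3 is estimated at 50000 nM in this assay, with a range from 15000 nM to 100000 nM.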

Compound 3, half-maximal cytotoxic concentration: > 100000 nM
Compound 3 gave a limit, no number (the forecaster's own chance of this, stated with the estimate: 35%); middle value at least 2.0-fold (0.30 log units) away from the limit.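

In this assay, exchanging the group on the sulfonyl sulfur gives an at least 1.5-fold higher number from compound 1 to compound 3 (0.20 log units; that floor lies within the scatter). For the compounds shown here, this is the first comparison of two compounds that differ in one place, and it shows that this position can hold a five-membered aromatic ring bearing chlorine with no sign of a lower number. The true size of the step stays unknown because the value of compound 3 is a limit of the assay and not a number: the limit of > 100000 nM in this assay, at which 2 of the 3 values shown sit.

The ring and the chlorine changed together, so their separate shares in the step cannot be told apart. From the compounds shown here alone, whether an amine or a carboxylic acid on this ring would give a lower or a higher number also remains open.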